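The source may hold more compounds than are shown below. What is called first, only, known or untested is meant among the compounds shown, and "the series" means these compounds.

Measured so far:
- compound 1 `Cc1nc(SCC(=O)Nc2nc(-c3ccc(Cl)cc3)cs2)n(Nc2ccccc2)c1C`: 45400 nM
- compound 2 `Cc1ccc(Nn2c(SCC(=O)Nc3nc(-c4ccccc4)cs3)nc(C)c2C)cc1`: > 100000 nM

For the measured compounds named here, in a functional assay on DU-145 cells (Homo sapiens) for antiproliferative activity, read by sulforhodamine B assay, with a stated time of 48 h (a higher number here means that more compound is tolerated, a lower number that less compound is tolerated), compound 1 gives 45400 nM; this is the only plain number in the set. For compound 2 the result in this assay is a limit of the assay, > 100000 nM, and no number. The set thus has (the limit of > 100000 nM in this assay, at which 1 of the 2 values shown sits). Going by the values given here, compound 1 and compound 2 differ in more than one place, so their two values mark no single step; they show only that one gives a number and the other a limit.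

Compound 3 `COc1ccc(Nn2c(SCC(=O)Nc3nc(-c4ccc(Cl)cc4)cs3)nc(C)c2C)cc1` is not yet measured. It differs from compound 1 by methoxy in place of hydrogen on an aromatic carbon. Among the compounds with values here, no measured pair isolates this change, so there is no step to lean on. The expectation is a modest shift toward less compound tolerated in this assay, or no step beyond the scatter, since compound 1 with 45400 nM already gives a high value. For compound 3 the estimate is 60000 nM, between 20000 nM and 120000 nM, a step of a 1.3-fold higher number from compound 1 to compound 3 (0.12 log units; within the scatter) from compound 1, with a fair chance that only a limit is reported.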

Compound 3, concentration lethal to 50% of the cells: > 100000 nM
Compound 3: a limit, no number (the forecaster's own chance of this, stated with the estimate: 35%); middle value at least 1.6-fold (0.22 log units) away from the limit.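

In this assay, for the compounds shown here, anilino to (4-methoxyphenyl)amino is the first change that can be read in isolation, and methoxy in place of hydrogen on this aromatic carbon, para to a large group, gives an at least 2.2-fold higher number from compound 1 to compound 3 (0.34 log units; beyond the scatter). Compound 3 gives > 100000 nM, which is a limit of the assay and not a number, so the step has a lower bound but no measured size. At this position, methoxy therefore takes the series from a plain number to a limit, leaving compound 1 as the only compound with a plain number: the limit of > 100000 nM in this assay, at which 2 of the 3 values shown sit.

Going by these compounds, whether the same direction holds for other groups at this position, such as fluoro, an amine or a carboxylic acid, remains open, as does the outcome for methoxy elsewhere on the ring. Going by these compounds alone, no pair isolates the methyl group of compound 2 or the chloro group of compound 1, so the effects of those changes cannot be read.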